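Ring amine against open-chain amine in microsomal stability

The compounds below may be only part of what the source reports. "The series", "measured", "known", "first", "only" and "open" are said of these compounds alone.

Three compounds have been measured in an ADME assay (liver, Mus musculus) for metabolic stability, read by LC-MS, using microsomes, tested at 1 uM; a lower number here means that the compound disappears faster, a higher number that the compound lasts longer:
Compound 1 `CCN(CC)CCCCCN/C(C)=N\c1ccnc2cc(Cl)ccc12`: > 1 h, a limit of the assay.
Compound 2 `C/C(=N/c1ccnc2cc(Cl)ccc12)NCCCCN1CCCCC1`: > 1 h, a limit of the assay.
Compound 3 `CC(C)/C(=N/c1ccnc2cc(Cl)ccc12)NCCCN1CCCCC1`: 0.717 h.

Compound 4 `CCN(CC)CCCCN/C(=N\c1ccnc2cc(Cl)ccc12)C(C)C` is not yet measured in this assay. It differs from compound 3 by (diethylamino)methyl in place of piperidin-1-yl on a saturated chain carbon, three bonds along the chain from an amine nitrogen. The same kind of change leads from compound 2 to compound 1, there as (diethylamino)methyl in place of piperidin-1-yl on a saturated chain carbon, four bonds along the chain from an amine nitrogen; the places differ only in lying three bonds or four bonds along the chain from an amine nitrogen. That measured step, a step that the two limits leave unreadable from compound 2 to compound 1, has no readable size because the limit of > 1 h in this assay, at which 2 of the 3 values shown sit, covers both of its ends. The difference between the core of compound 2 and the core of compound 3 is not broken down here. Among the measured compounds shown here, the one measured example of this change therefore gives no size to build on. For compound 4 a step of a 1.1-fold higher number from compound 3 to compound 4 (0.05 log units; within the scatter) from compound 3 is expected, small enough to sit within ordinary scatter. Compound 4 is estimated at 0.8 h, plausibly between 0.35 h and 2 h.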

Compound 4, half-life: 0.7 h
Compound 4: the middle estimate sits 1.1-fold (0.06 log units) above what was measured; the range from low to high includes it.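

In this assay, putting (diethylamino)methyl in place of piperidin-1-yl gives a 1.0-fold lower number from compound 3 to compound 4 (0.01 log units; within the scatter), so on this core the open-chain amine and the ring amine cannot be told apart. The same change, four bonds along the chain from an amine nitrogen, leads from compound 2 to compound 1, but that step cannot be read because both of its ends are a limit and not a number: the limit of > 1 h in this assay, at which 2 of the 4 values shown sit. The readable step therefore describes one core only and does not show whether the change carries over to another.

From the compounds shown here alone, it remains open whether a pyrrolidine or a morpholine in place of piperidin-1-yl would give a similar half-life on the core of compound 3. Going by these compounds, a longer chain on that core is equally open.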